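A few compounds are considered here, and "the series" means these few. Any claim that something is new, unique, unknown or untested is made for them only; others in the source may bear on it.

Working notes on the series. In a functional assay on MCF7 cells (Homo sapiens) for cytotoxicity, read by sulforhodamine B assay, with a stated time of 24 h (a higher number here means a weaker inhibitor, a lower number a stronger inhibitor), compound 1 (`O=C1Nc2ccc(S(=O)(=O)N3CCOCC3)cc2/C1=N/c1ccc(Br)cc1`) gives 44800 nM, compound 2 (`N/N=C1\C(=O)Nc2ccc(S(=O)(=O)N3CCOCC3)cc21`) gives 46800 nM and compound 3 (`O=C1Nc2ccc(S(=O)(=O)N3CCOCC3)cc2/C1=N/c1ccc(C(=O)O)cc1`) gives 26700 nM. Compound 3 therefore sits within the scatter of both other compounds, with a 1.7-fold lower number from compound 1 to compound 3 (0.22 log units; within the scatter) and a 1.8-fold lower number from compound 2 to compound 3 (0.24 log units; within the scatter).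

The next compound, compound 4 (`O=C1Nc2ccc(S(=O)(=O)N3CCOCC3)cc2/C1=N/NS(=O)(=O)c1ccccc1`), has (phenylsulfonyl)amino in place of 4-carboxyphenyl on a double-bonded nitrogen. The closest evidence comes from the earlier exchanges on that nitrogen, a 1.0-fold higher number from compound 1 to compound 2 (0.02 log units; within the scatter) and a 1.8-fold lower number from compound 2 to compound 3 (0.24 log units; within the scatter). The exchange on the aromatic carbon, also given above, is likewise small. Within the data shown here, no measured compound yet carries the entering group, so this support is indirect.

No step beyond the scatter is therefore expected in this assay. The expected change is an estimated 1.4-fold higher number from compound 3 to compound 4 (0.15 log units; within the scatter). Compound 4 is estimated at 38000 nM, with an expected range of 17000 nM to 85000 nM.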

Compound 4, half-maximal inhibitory concentration: 25300 nM
Compound 4: the middle estimate sits 1.5-fold (0.18 log units) above what was measured; low and high end bracket the measured number.
By their numbers in this assay, from the lowest: compounds 4, 3, 1 and 2 (each within the scatter of the next).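

On the double-bonded nitrogen whose other neighbours are carbon with a double bond to nitrogen, (phenylsulfonyl)amino stays within the scatter of all three earlier groups in this assay (a 1.1-fold lower number from compound 3 to compound 4 (0.02 log units; within the scatter)) (a 1.8-fold lower number from compound 2 to compound 4 (0.27 log units; within the scatter)) (a 1.8-fold lower number from compound 1 to compound 4 (0.25 log units; within the scatter)). The series now adds a sulfonyl-bearing group at this place, and placing phenylsulfonyl on the amine nitrogen of compound 2 also gives no step beyond the scatter, so none of the four compounds separates from the others in this assay. No measured evidence accompanying these compounds bears on the reason for this.

From the compounds shown here alone, whether a longer alkyl chain on that nitrogen would give a step beyond the scatter remains open. Going by these compounds, the shared core is unchanged across the four compounds, so the effect of placing a group such as a nitrile on it also remains open.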